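This account rests on a few compounds, and the source may have more. Where it says the series, first, only, none or still open, it means among the compounds named here.

Measured compounds:
Compound 1, `Cc1ccc(S(=O)(=O)/N=C(/CCNC2=CC(=O)c3ccccc3C2=O)Nc2ccc(F)cc2)cc1` — 9330 nM
Compound 2, `Cc1ccc(S(=O)(=O)/N=C(/CCNC2=CC(=O)c3ccccc3C2=O)Nc2ccccc2[N+](=O)[O-])cc1` — 5010 nM
Compound 3, `COc1ccc(N/C(CCNC2=CC(=O)c3ccccc3C2=O)=N\S(=O)(=O)c2ccc(C)cc2)c(OC)c1` — 126000 nM

In a functional assay on A549 cells (Homo sapiens) for cytotoxicity, read by MTT assay, with a stated time of 48 h (on this read-out lower numbers stand for stronger inhibition and higher numbers for weaker inhibition), compound 2 gives the lowest of the three numbers, while compound 1 sits within the scatter of it, as the step of a 1.9-fold lower number from compound 1 to compound 2 (0.27 log units; within the scatter) shows. Compound 3 stands far off: a 25-fold higher number from compound 2 to compound 3 (1.40 log units; beyond the scatter) and a 14-fold higher number from compound 1 to compound 3 (1.13 log units; beyond the scatter) are both large. Compound 4, `COc1cc(N/C(CCNC2=CC(=O)c3ccccc3C2=O)=N\S(=O)(=O)c2ccc(C)cc2)cc(OC)c1OC`, carries the change (3,4,5-trimethoxyphenyl in place of 2-nitrophenyl on an amine nitrogen). The step that bears on it is a 25-fold higher number from compound 2 to compound 3 (1.40 log units; beyond the scatter), where a methoxy-bearing phenyl replacing the 2-nitrophenyl gave a large rise; a similar rise is expected for the 3,4,5-trimethoxyphenyl. Compound 4 is therefore estimated at 100000 nM, within 25000 nM to 400000 nM, a step of a 20-fold higher number from compound 2 to compound 4 (1.30 log units; beyond the scatter).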

Compound 4, half-maximal inhibitory concentration: 7940 nM
Compound 4: middle estimate off by 13-fold (1.10 log units), on the high side; the whole stated range lies above it.
By their numbers in this assay, from the lowest: compounds 2, 4 and 1 (each within the scatter of the next); then compound 3.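

In this assay, a methoxy-bearing phenyl on the amine nitrogen need not bring the large rise seen earlier: the 3,4,5-trimethoxyphenyl gives a 1.6-fold higher number from compound 2 to compound 4 (0.20 log units; within the scatter) and a 1.2-fold lower number from compound 1 to compound 4 (0.07 log units; within the scatter). The two methoxy-bearing groups themselves are far apart, with a 16-fold lower number from compound 3 to compound 4 (1.20 log units; beyond the scatter), so among these compounds the presence of methoxy alone does not set the value, and compound 3 alone stands off.

As far as these compounds go, it remains open whether a phenyl with a single methoxy group, or one carrying an amine or a carboxylic acid, would stay with compound 1, compound 2 and compound 4 or move towards compound 3. Nothing shown accounts for the distance of compound 3 from the others.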